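The source may hold more compounds than are shown below. What is called first, only, known or untested is meant among the compounds shown, and "the series" means these compounds.

Measured so far in a functional assay with Alpha-1A adrenergic receptor (Homo sapiens) as the target, read by calcium flux; on this read-out lower numbers stand for smaller maximal responses and higher numbers for larger maximal responses:
- compound 1, `Cn1cccc1-c1ccccc1NCC1=NCCN1`: 103%
- compound 2, `Cc1n[nH]c(-c2ccccc2NCC2=NCCN2)n1`: 87%
- compound 3, `Cn1ncnc1-c1ccccc1NCC1=NCCN1`: 91%

Compound 3 sits within the scatter of compound 2 and beyond the scatter below compound 1, the highest number of the three. Compound 4, `c1ccc(-c2cn[nH]c2)c(NCC2=NCCN2)c1`, differs from compound 3 by 1H-pyrazol-4-yl in place of 1-methyl-1H-1,2,4-triazol-5-yl on an aromatic carbon.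

Bearing on this change: a number 12 percentage points lower from compound 1 to compound 3 (beyond the scatter) and a number 16 percentage points lower from compound 1 to compound 2 (beyond the scatter), both modest drops on exchanging the five-membered ring; a number 4 percentage points higher from compound 2 to compound 3 (within the scatter), within the scatter. Going by the values given here, no measured step reaches a 1H-pyrazol-4-yl ring, so the expected step of a number 1 percentage points higher from compound 3 to compound 4 (within the scatter) is small, with no direction beyond the scatter, because a number 4 percentage points higher from compound 2 to compound 3 (within the scatter) shows little movement between the related rings. Compound 4 is estimated at 92%, with a range of 78% to 106%.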

Compound 4, largest response reached (reported as maximal response), in percent of the reference or control that the assay uses: 112%
Compound 4: the middle estimate sits 20 percentage points below what was measured, outside the stated range (above it).
By their numbers in this assay, from the lowest: compounds 2 and 3 (each within the scatter of the next); then compounds 1 and 4 (each within the scatter of the next).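

In this assay, going by these compounds alone, the choice of five-membered ring on this aromatic carbon matters more than the earlier steps showed: 1H-pyrazol-4-yl gives a number 21 percentage points higher from compound 3 to compound 4 (beyond the scatter) and a number 25 percentage points higher from compound 2 to compound 4 (beyond the scatter) on exchange of a triazolyl ring. Against 1-methyl-1H-pyrrol-2-yl it gives a number 9 percentage points higher from compound 1 to compound 4 (within the scatter) and so the two triazolyl compounds stand apart from the pair of compounds 1 and 4. Nothing available explains the separation between these rings.

Open, on these data alone, is whether a five-membered ring is needed here at all: an amine, a carboxylic acid or a phenyl group on this carbon would test that.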